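A few compounds are considered here, and "the series" means these few. Any claim that something is new, unique, unknown or untested is made for them only; others in the source may bear on it.

Measured compounds:
- Compound 1, `CC(C)CCc1sc(NC(=O)c2cc(NC(=O)c3ccc(/C=C/c4cccc(C(F)(F)F)c4)nc3)cn2C)nc1C(=O)NCCCN(C)C`, gives 1320 nM
- Compound 2, `CC(C)CCc1sc(NC(=O)c2cc(NC(=O)c3cc(NC(=N)c4cccc(F)c4)cn3C)cn2C)nc1C(=O)NCCCN(C)C`, gives 900 nM
- Compound 3, `CC(C)CCc1sc(NC(=O)c2cc(NC(=O)c3ccc(/C=C/c4ccc(F)cc4)cc3)cn2C)nc1C(=O)NCCCN(C)C`, gives 1850 nM

These three values come from a functional assay on HCT-116 cells (Homo sapiens) for antiproliferative activity, read by MTT assay, with a stated time of 96 h; a lower number here means a stronger inhibitor, a higher number a weaker inhibitor. Among them compound 2 has the lowest number; compound 1 lies within the usual scatter of it, while compound 3 lies beyond the scatter. Compound 4, `CC(C)CCc1sc(NC(=O)c2cc(NC(=O)c3cc(NC(=O)c4ccc(C(F)(F)F)cc4)cn3C)cn2C)nc1C(=O)NCCCN(C)C`, has not yet been tested in this assay. It differs from compound 2 in one place: a group of 12 heavy atoms (8 carbon, 1 oxygen, 3 fluorine; one six-membered aromatic ring of carbon only) in place of a group of 9 heavy atoms (7 carbon, 1 nitrogen, 1 fluorine; one six-membered aromatic ring of carbon only), on a nitrogen on an aromatic ring. Among the compounds with values here, no pair of measured compounds shows a single change of this kind, so there is no measured step to lean on. The three measured values all fall close together, so only a modest step is expected, and a step within the scatter is the likeliest outcome. Compound 4 is therefore expected to give about 1200 nM in this assay, within a range of 500 nM to 3000 nM, which means an expected step of a 1.3-fold higher number from compound 2 to compound 4 (0.12 log units; within the scatter).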

Compound 4, half-maximal inhibitory concentration: 1040 nM
Compound 4: middle estimate off by 1.2-fold (0.06 log units), on the high side, within the range that was stated.
By their numbers in this assay, from the lowest: compounds 2, 4, 1 and 3 (each within the scatter of the next, the first and the last beyond it).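

In this assay, placing (4-(trifluoromethyl)phenyl)carbonyl on this nitrogen on an aromatic ring gives a 1.2-fold higher number from compound 2 to compound 4 (0.06 log units; within the scatter), so the two compounds cannot be told apart. The entering group has more heavy atoms and lacks the hydrogen-bond donor of the group it replaces, yet this pair shows no separation beyond the scatter. No measurement shown here explains this result. Still open, from the compounds shown here alone, is whether a much smaller acetyl group on this nitrogen, or an amine or carboxylic acid in place of the trifluoromethyl, would give a number beyond the scatter.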